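Aryl swaps on a shared core: toxicity toward Vero cells

The source may report more compounds than this note shows. Statements on the series, on what has been measured and on what is new or still open speak of the compounds shown alone.

Compound 1 `O=C1CSC(c2cccc(O)c2)N1CCN1CCCCC1`: 13% in an ADME assay on Vero cells (Chlorocebus sabaeus) for cytotoxicity, read by neutral red uptake, tested at 1575 ug/mL; a higher number here means a weaker effect of the compound at the concentration tested, a lower number a stronger effect
Compound 2 `O=C1CSC(c2ccc(O)cc2)N1CCN1CCCCC1`: 12%
Compound 3 `Cc1ccc(C2SCC(=O)N2CCN2CCCCC2)cc1`: 13%

Compound 3 stands level with compound 1 at the digits shown, the two together the highest of the three numbers; its nearest neighbour is compound 1, with no change at the digits printed from compound 1 to compound 3 (within the scatter), and its furthest is compound 2, with a number 1 percentage points higher from compound 2 to compound 3 (within the scatter). The step to compound 4 `O=C1CSC(c2ccccc2Cl)N1CCN1CCCCC1` is 2-chlorophenyl in place of 4-methylphenyl on a saturated ring carbon. Every measured step also swaps the aryl group on that saturated ring carbon, and each stayed within the scatter: a number 1 percentage points lower from compound 1 to compound 2 (within the scatter), no change at the digits printed from compound 1 to compound 3 (within the scatter) and a number 1 percentage points higher from compound 2 to compound 3 (within the scatter). A step within the scatter is therefore expected for compound 4 as well, no change at the digits printed from compound 3 to compound 4 (within the scatter). Compound 4 is estimated at 13%, expected to lie between 5% and 22%.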

Compound 4, a percentage reported as activity, at one concentration (the size of the read-out at that concentration, not a potency): 16%
Beside the measured number, compound 4's estimate is 3 percentage points below it; the range from low to high includes it.
By their numbers in this assay, from the lowest: compounds 2, 1, 3 and 4 (each within the scatter of the next).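

Compound 4 places 2-chlorophenyl on the saturated ring carbon, and in this assay the read-out stays within the scatter of all three earlier compounds (a number 3 percentage points higher from compound 3 to compound 4 (within the scatter)), (a number 4 percentage points higher from compound 2 to compound 4 (within the scatter)) and (a number 3 percentage points higher from compound 1 to compound 4 (within the scatter)). This position therefore accepts a chlorine-bearing aryl group as well as the hydroxyphenyl and methylphenyl groups without a step beyond the scatter. Nothing shown offers an explanation for these numbers. Still open, as far as these compounds go, is whether an aryl group carrying an amine or a carboxylic acid would leave the number in the same place. Also open, from the compounds shown here alone, is whether a longer chain in place of the aryl group would do so.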